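This account rests on a few compounds, and the source may have more. Where it says the series, first, only, none or still open, it means among the compounds named here.

Compound 1, `CC(C)(N)CC(=O)N[C@@H]1CCc2ccccc2N(Cc2ccc(-c3ccccc3-c3nnn(Cc4ccccc4)n3)cc2)C1=O`, has been tested in a functional assay (Pituitary gland cell) with Rattus norvegicus as the target (a lower number here means that less compound is needed, a higher number that more compound is needed for the effect), where compound 1 gives 1 uM. Among the three compounds with numbers, compound 1 stands second highest. Compound 2, `CC(C)(N)CC(=O)N[C@@H]1CCc2ccccc2N(Cc2ccc(-c3ccccc3-c3nnnn3Cc3ccccc3)cc2)C1=O`, gives 0.7 uM, and the change of a 1.4-fold lower number from compound 1 to compound 2 (0.15 log units; within the scatter) lies within the scatter. Compound 3, `CC(C)(N)CC(=O)N[C@@H]1CCc2ccccc2N(Cc2ccc(-c3ccccc3S(N)(=O)=O)cc2)C1=O`, gives 3 uM; the step of a 3.0-fold higher number from compound 1 to compound 3 (0.48 log units; beyond the scatter) is beyond the scatter, as is the step of a 4.3-fold higher number from compound 2 to compound 3 (0.63 log units; beyond the scatter). Compound 4, `CC(C)(N)CC(=O)N[C@@H]1CCc2ccccc2N(Cc2ccc(-c3ccccc3S(=O)(=O)NC(=O)c3ccccc3)cc2)C1=O`, has not yet been measured. It differs from compound 1 in one place: benzoylsulfamoyl in place of 2-benzyl-2H-tetrazol-5-yl on an aromatic carbon. Among the measured compounds shown here, the steps that bear on this change are the two leading to compound 3, in which a sulfamoyl took the place of either benzyl tetrazole and the number rose modestly. Compound 4 also carries a sulfamoyl, but one bearing a benzoyl, so it keeps a second six-membered aromatic ring of carbon only, as the benzyl tetrazoles did. A step toward a higher number is therefore expected, but smaller than the step to compound 3 and close to the edge of the scatter. The expected step is a 1.6-fold higher number from compound 1 to compound 4 (0.20 log units; within the scatter). Compound 4 is estimated to give about 1.6 uM in this assay, with a likely range from 0.6 uM to 4.5 uM.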

Compound 4, concentration for half-maximal effect: 3 uM
The estimate for compound 4 lay 1.9-fold (0.27 log units) below the measured number; the range from low to high includes it.
By their numbers in this assay, from the lowest: compounds 2 and 1 (each within the scatter of the next); then compounds 3 and 4 (each within the scatter of the next).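

In this assay adding a benzoyl on the sulfonamide nitrogen gives no change at the digits printed from compound 3 to compound 4 (within the scatter) and so shows that a six-membered aromatic ring of carbon only, added to the sulfamoyl, does not bring the number back to that of the benzyl tetrazoles. Benzoylsulfamoyl matches 2-benzyl-2H-tetrazol-5-yl in heavy atoms and keeps that ring, yet it gives a 3.0-fold higher number from compound 1 to compound 4 (0.48 log units; beyond the scatter) and a 4.3-fold higher number from compound 2 to compound 4 (0.63 log units; beyond the scatter) with the same step sizes as the plain sulfamoyl. Among these four compounds, what separates the numbers at this place is therefore the tetrazole or sulfonyl link, not the presence of the second ring. Still open, on these data alone, is whether a carboxylic acid or an unsubstituted tetrazole here would fall with the benzyl tetrazoles or with the sulfonyl groups. Nothing measured here explains the difference between these two sets of compounds.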